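Alkyne-tethered quinoline thioethers: estimate for compound 4

The source may hold more compounds than are shown below. What is called first, only, known or untested is meant among the compounds shown, and "the series" means these compounds.

Measured so far in a functional assay on CCRF-CEM cells (Homo sapiens) for cytotoxicity, read by sulforhodamine B assay, with a stated time of 72 h; on this read-out higher numbers stand for weaker inhibition and lower numbers for stronger inhibition:
- compound 1, `OCC#CCSc1cnc2ccccc2c1[Se]CC#CCBr`: 0.2 ug/mL
- compound 2, `OCC#CCSc1cnc2ccccc2c1SCC#CCBr`: 0.6 ug/mL
- compound 3, `CSc1c(SCC#CCO)cnc2ccccc12`: 13.9 ug/mL

Compound 3 gives the highest number of the three, standing a 23-fold higher number from compound 2 to compound 3 (1.36 log units; beyond the scatter) away from compound 2 and further still from compound 1, as a 70-fold higher number from compound 1 to compound 3 (1.84 log units; beyond the scatter) shows. Compound 4, `C#CCSc1c(SCC#CCO)cnc2ccccc12`, differs from compound 3 by ethynyl in place of hydrogen on a saturated chain carbon bound to a sulfur.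

Within the data shown here, the step that bears most directly on this is the one from compound 2 to compound 3, where a hydrogen took the place of a group of 4 heavy atoms on the same saturated chain carbon bound to a sulfur and the number rose by a 23-fold higher number from compound 2 to compound 3 (1.36 log units; beyond the scatter). Compound 4 restores part of a chain at that position, so a drop in the number is expected in this assay, though the ethynyl carries no bromine and is shorter than the group lost between compound 2 and compound 3, so only part of that step is expected to be recovered. The estimate for compound 4 is therefore 4 ug/mL with a range of 1.5 ug/mL to 12 ug/mL, which corresponds to an expected step of a 3.5-fold lower number from compound 3 to compound 4 (0.54 log units; beyond the scatter).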

Compound 4, concentration for 50% inhibition: 2.7 ug/mL
Compound 4: the middle estimate sits 1.5-fold (0.17 log units) above what was measured, and the stated range covers the measured number.
By their numbers in this assay, from the lowest: compound 1; then compound 2; then compound 4; then compound 3.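

In this assay, among these compounds, ethynyl in place of hydrogen on a saturated chain carbon bound to a sulfur lowers the number without any bromine present (a 5.1-fold lower number from compound 3 to compound 4 (0.71 log units; beyond the scatter)), so the change from methylsulfanyl to propargylsulfanyl separates part of the effect of the chain from that of the halogen, which the earlier compounds could not do. Bromomethyl in place of hydrogen on a triple-bonded carbon still matters, as the reverse change shows (a 4.5-fold higher number from compound 2 to compound 4 (0.65 log units; beyond the scatter)), and the step to the selenium-bearing bromo group on the aromatic carbon remains large (a 14-fold higher number from compound 1 to compound 4 (1.13 log units; beyond the scatter)). No evidence on the cause of these steps is available.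

The compounds shown leave open whether the triple bond itself is needed, since a saturated propyl group is not among them. They also leave open whether bromine can be replaced at that chain end, for example by chlorine or an amine.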